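The compounds below may be only part of what the source reports. "The series", "measured", "known", "first", "only" and "open" are said of these compounds alone.

Compound 1, `O=C(Nc1ccc(Sc2nc3ccccc3s2)cc1)c1cc(Br)cc(Br)c1O`, was tested in a functional assay on HCT-116 cells (Homo sapiens) for cytotoxicity, read by resazurin assay, with a stated time of 48 h (a higher number here means that more compound is needed for the effect, a lower number that less compound is needed), where compound 1 gives 19000 nM. Within the data shown here, the only other measured compound, compound 2, `COc1ccc(S(=O)(=O)Nc2ccc(-c3nc4cc(NS(=O)(=O)c5ccc(OC)cc5)ccc4o3)cc2)cc1`, gives 12000 nM in this assay. Compound 1 thus has the highest of the two numbers, and compound 2 is its nearest neighbour, but the gap between them lies within the usual scatter, so the two cannot be told apart on these numbers. Compound 3, `COc1c(Br)cccc1C(=O)Nc1ccc(Sc2nc3ccccc3s2)cc1`, is not yet measured. It differs from compound 1 in one place: a group of 9 heavy atoms (7 carbon, 1 oxygen, 1 bromine; one six-membered aromatic ring of carbon only) in place of a group of 9 heavy atoms (6 carbon, 1 oxygen, 2 bromine; one six-membered aromatic ring of carbon only), on a carbonyl carbon. Among the measured compounds shown here, no step between two measured compounds is available to show what such a change does, so the expected step of a 1.1-fold higher number from compound 1 to compound 3 (0.02 log units; within the scatter) is small, with no direction beyond the scatter. For compound 3 in this assay the estimated value is 20000 nM, with a range from 6000 nM to 60000 nM.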

Compound 3, half-maximal effective concentration: 31000 nM
Beside the measured number, compound 3's estimate is 1.6-fold (0.19 log units) below it; the range from low to high includes it.
By their numbers in this assay, from the lowest: compounds 2, 1 and 3 (each within the scatter of the next, the first and the last beyond it).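

Putting the new group on the carbonyl carbon in place of 3,5-dibromo-2-hydroxyphenyl gives a 1.6-fold higher number from compound 1 to compound 3 (0.21 log units; within the scatter) in this assay, so this change cannot be told apart from repeat-measurement noise. Among these compounds, the swap replaces a group with 1 hydrogen-bond donor by one with 0 hydrogen-bond donors and also alters the bromine count, yet the reading stays within the scatter, which the earlier compounds could not show for this position. Nothing measured here offers an explanation for this result.

On these data alone, because the donor and the bromine count change together in this one step, their separate contributions remain unknown. As far as these compounds go, it also remains open whether a ring on this carbonyl carbon bearing an amine or a carboxylic acid would shift the number beyond the scatter.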